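Removing the tert-butyl group from compound 2's benzyl ring

The compounds below may be only part of what the source reports. "The series", "measured", "known", "first", "only" and "open" are said of these compounds alone.

The series shares one core, carrying a bis(trifluoromethyl)phenylsulfonamide joined through a three-carbon chain to a benzylic amine, and varies only the aryl group on that benzylic carbon. Compound 1 `O=S(=O)(NCCCNCc1ccccc1Cl)c1cc(C(F)(F)F)cc(C(F)(F)F)c1` gives 8800 nM in a functional assay on MCF7 cells (Homo sapiens) for inhibition, read by MTT assay, with a stated time of 72 h; on this read-out lower numbers stand for stronger inhibition of growth and higher numbers for weaker inhibition of growth. Compound 2 `CC(C)(C)c1ccc(CNCCCNS(=O)(=O)c2cc(C(F)(F)F)cc(C(F)(F)F)c2)cc1` gives 2100 nM in this assay, the lowest of the three numbers, and compound 3 `O=S(=O)(NCCCNCc1ccc(Cl)c(C(F)(F)F)c1)c1cc(C(F)(F)F)cc(C(F)(F)F)c1` gives 3500 nM. The steps show a 4.2-fold lower number from compound 1 to compound 2 (0.62 log units; beyond the scatter) and a 2.5-fold lower number from compound 1 to compound 3 (0.40 log units; beyond the scatter), while a 1.7-fold higher number from compound 2 to compound 3 (0.22 log units; within the scatter) lies within the scatter.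

Compound 4 `O=S(=O)(NCCCNCc1ccccc1)c1cc(C(F)(F)F)cc(C(F)(F)F)c1` is the unmeasured member. Its difference from compound 2 is hydrogen in place of tert-butyl on an aromatic carbon. Among the measured compounds shown here, no measured step removes a group from the benzyl ring outright; the closest guide is the step from compound 1 to compound 2, where a 4-(tert-butyl)phenyl gave a modest lower number than a 2-chlorophenyl. Taking the tert-butyl away is therefore expected to move the number upward by a 2.9-fold higher number from compound 2 to compound 4 (0.46 log units; beyond the scatter), a modest step. Compound 4 is thus estimated at 6000 nM, within a range of 2500 nM to 15000 nM.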

Compound 4, concentration for 50% growth inhibition: 3000 nM
Estimate against measurement, compound 4: 2.0-fold (0.30 log units) above; low and high end bracket the measured number.
By their numbers in this assay, from the lowest: compounds 2, 4 and 3 (each within the scatter of the next); then compound 1.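

Taking away the tert-butyl group leaves the number in this assay within the scatter, a 1.4-fold higher number from compound 2 to compound 4 (0.15 log units; within the scatter), so compound 2's activity here does not depend on that group. The bare phenyl ring also stays within the scatter of the more heavily substituted ring, a 1.2-fold lower number from compound 3 to compound 4 (0.07 log units; within the scatter), and so neither substituted ring in compounds 2 and 3 is set apart from it. Among the compounds shown here, the one step beyond the scatter is a 2.9-fold lower number from compound 1 to compound 4 (0.47 log units; beyond the scatter), with hydrogen in place of chloro, which shows that the chloro group in compound 1 is what separates that compound from the unsubstituted one.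

Nothing given explains any of these steps. As far as these compounds go, it remains open whether chloro on another ring carbon would behave the same way, and how a methoxy group, an amine or a carboxylic acid on the ring, or a longer chain in the linker, would read.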